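The compounds below may be only part of what the source reports. "The series", "measured", "known", "first", "only" and "open" are said of these compounds alone.

Compound 1 `C[C@@H](O)[C@H](NC(=O)CN(c1nc(Cl)nc2[nH]cnc12)C1CC1)C(=O)OCc1ccccc1` is the stronger of two measured compounds in a functional assay on the whole organism (Tail, strain ICR) with Mus musculus as the target, in the tail flick test, with a stated time of 30 min, at a dose of 25 umol/kg by the oral route (on this read-out higher numbers stand for a stronger effect at the one dose given and lower numbers for a weaker effect), where compound 1 gives 21.9%. Among the compounds with values here, compound 2 `C[C@@H](O)[C@H](NC(=O)CN(c1nc(Cl)nc2[nH]cnc12)C1CC1)C(=O)O` gives 18.6%, and the only measured step, a number 3.3 percentage points lower from compound 1 to compound 2 (within the scatter), concerns a different part of the molecule. Compound 3 `CSCC[C@H](NC(=O)CN(c1nc(Cl)nc2[nH]cnc12)C1CC1)C(=O)OCc1ccccc1` differs from compound 1 by 2-(methylsulfanyl)ethyl in place of 1-hydroxyethyl on a saturated chain carbon bound to an amide-type nitrogen and a carbonyl carbon. No measured step touches this position, so nothing shown bears directly on it, and the one step seen was small. Compound 3 is therefore expected to sit close to compound 1, with a step of about a number 0.1 percentage points higher from compound 1 to compound 3 (within the scatter). Compound 3 is estimated at 22%, between 8% and 38%.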

Compound 3, a percentage reported as activity, at one dose (the size of the read-out at that dose, not a potency): 22.2%
Compound 3: middle estimate off by 0.2 percentage points, on the low side, and the stated range covers the measured number.
By their numbers in this assay, from the lowest: compounds 2, 1 and 3 (each within the scatter of the next).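

Within the data shown here, on a saturated chain carbon bound to an amide-type nitrogen and a carbonyl carbon, 2-(methylsulfanyl)ethyl in place of 1-hydroxyethyl gives a number 0.3 percentage points higher from compound 1 to compound 3 (within the scatter) in this assay and so provides the only measured step at this position. The change swaps the oxygen-bearing group, with its hydrogen-bond donor, for a sulfur-bearing group with none, and the read-out stays within the scatter. Nothing available explains this result. On these data alone, whether an amine, a carboxylic acid or a longer chain at this position would shift the read-out remains open.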